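The compounds below may be only part of what the source reports. "The series", "measured", "known", "first", "only" and "open" are said of these compounds alone.

Measured compounds in an assay on isolated protein (Cavia porcellus) with Sigma non-opioid intracellular receptor 1 (Homo sapiens) as the target, read by radioligand binding; on this read-out higher numbers stand for weaker inhibition and lower numbers for stronger inhibition:
compound 1, `CN(C)CCCCCCCCCOc1ccc2oc(-c3ccccc3)cc(=O)c2c1`, 202 nM;
compound 2, `CN(C)CCCCCCCCCCOc1ccc2oc(-c3ccccc3)cc(=O)c2c1`, 341 nM;
compound 3, `O=c1cc(-c2ccccc2)oc2ccc(OCCCCCCN3CCC(O)CC3)cc12`, 121 nM.

Compound 3 gives the lowest number of the three; its gap to compound 1 lies within the scatter, its gap to compound 2 beyond it, a 2.8-fold lower number from compound 2 to compound 3 (0.45 log units; beyond the scatter).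

Compound 4, `CN(CCCCCCOc1ccc2oc(-c3ccccc3)cc(=O)c2c1)Cc1ccccc1`, differs from compound 3 by benzyl(methyl)amino in place of 4-hydroxypiperidin-1-yl on a saturated chain carbon, six bonds along the chain from an oxygen on an aromatic ring. Among the compounds with values here, the steps that bear on this are the two changes of the amine terminus: a 1.7-fold lower number from compound 1 to compound 3 (0.22 log units; within the scatter) and a 2.8-fold lower number from compound 2 to compound 3 (0.45 log units; beyond the scatter), both small. Changing the amine has so far moved this assay only modestly, so for compound 4 a step of no more than modest size in either direction is expected, a 1.1-fold higher number from compound 3 to compound 4 (0.03 log units; within the scatter). Compound 4 is estimated at 130 nM, between 45 nM and 400 nM.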

Compound 4, half-maximal inhibitory concentration: 75 nM
Estimate against measurement, compound 4: 1.7-fold (0.24 log units) above, within the range that was stated.
By their numbers in this assay, from the lowest: compounds 4, 3, 1 and 2 (each within the scatter of the next, the first and the last beyond it).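

In this assay, benzyl(methyl)amino on the saturated chain carbon six bonds along the chain from an oxygen on an aromatic ring gives a number level with that of 4-hydroxypiperidin-1-yl (a 1.6-fold lower number from compound 3 to compound 4 (0.21 log units; within the scatter)), so the swap to an aromatic ring of carbon only, with no hydrogen-bond donor, leaves the read-out within the scatter. The steps from the dimethylamino compounds go beyond the scatter (a 4.5-fold lower number from compound 2 to compound 4 (0.66 log units; beyond the scatter); a 2.7-fold lower number from compound 1 to compound 4 (0.43 log units; beyond the scatter)), but chain length and amine change together in both. No available evidence explains these steps. Open, as far as these compounds go, is how dimethylamino performs on the same six-bond chain, and whether a longer chain retains the number with benzyl(methyl)amino. A plain piperidine or a morpholine at this place also remains untested in the compounds shown.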